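This account rests on a few compounds, and the source may have more. Where it says the series, first, only, none or still open, it means among the compounds named here.

Compound 1, `O=S(=O)(Nc1ccc(-c2nc3ccccc3o2)cc1)c1ccccc1Cl`, gives in an assay on isolated protein for inhibition of malate dehydrogenase, mitochondrial (Sus scrofa), with stated times of 45 min and 30 min (a lower number here means a stronger inhibitor, a higher number a weaker inhibitor), only the limit > 63000 nM.
Compound 2, `O=S(=O)(Nc1ccc2oc(-c3ccccc3)nc2c1)c1ccccc1Cl`, gives in this assay only the limit > 63000 nM.
Compound 3, `COc1ccc(S(=O)(=O)Nc2ccc3oc(-c4ccccc4)nc3c2)cc1`, gives in this assay only the limit > 63000 nM.

None of the three measured compounds yields a number in this assay; every value is a limit, and the limit of > 63000 nM in this assay, at which 3 of the 3 values shown sit, records that all three sit there. Compound 1 therefore stands nowhere in particular on these numbers: it shares the common limit and cannot be placed against compound 2 or compound 3. Among the measured compounds shown here, the one step between measured compounds, a step that the two limits leave unreadable from compound 2 to compound 3, is itself unreadable because the limit of > 63000 nM in this assay, at which 3 of the 3 values shown sit, sets both of its ends at the same limit, so it gives no guidance about what a change on the sulfonyl sulfur does.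

Compound 4, `Cc1cccc(S(=O)(=O)Nc2ccc(-c3nc4ccccc4o3)cc2)c1`, differs from compound 1 by 3-methylphenyl in place of 2-chlorophenyl on a sulfonyl sulfur. For the measured compounds named here, the only step on record that changes the group on the sulfonyl sulfur, a step that the two limits leave unreadable from compound 2 to compound 3, is unreadable, so no measured step says how large a step in this assay to expect, nor in which direction. Given (the limit of > 63000 nM in this assay, at which 3 of the 3 values shown sit), the expectation is that compound 4 again reports no number. Compound 4 is thus expected at 100000 nM, in a range from 40000 nM to 300000 nM. This estimate means an expected step that the limit leaves unreadable from compound 1 to compound 4, which is no step beyond the scatter.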

Compound 4, half-maximal inhibitory concentration: > 63000 nM
Compound 4: no number, only a limit; the forecaster's own chance of this, stated with the estimate: 85%; the middle value is on the limit's open side.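

No new step can be read between compound 1 and compound 4, since each gives only a limit in this assay, and the same holds across the series: the limit of > 63000 nM in this assay, at which 4 of the 4 values shown sit.

The compounds shown leave open how strongly any of them inhibits the enzyme, and whether any group on the sulfonyl sulfur would give a readable number in this assay.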